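Urea substituent swap: from cyclohexyl to benzamido

The source may report more compounds than this note shows. Statements on the series, on what has been measured and on what is new or still open speak of the compounds shown alone.

Values in a functional assay on MCF7 cells (Homo sapiens) for antiproliferative activity, read by MTT assay; a higher number here means a weaker inhibitor, a lower number a stronger inhibitor:
- compound 1 `COc1cc2c(Oc3ccc(NC(=O)Nc4ccccc4C(F)(F)F)cc3)ccnc2cc1OCCCCCCC(=O)NO`: 1080 nM
- compound 2 `COc1cc2c(Oc3ccc(NC(=O)Nc4ccc(Cl)c(C(F)(F)F)c4)cc3)ccnc2cc1OCCCCCCC(=O)NO`: 5150 nM
- compound 3 `COc1cc2c(Oc3ccc(NC(=O)NC4CCCCC4)cc3)ccnc2cc1OCCCCCCC(=O)NO`: 600 nM

Compound 3 sits at the low end of this small set, with 600 nM. The nearest measured neighbour is linked to it by a 1.8-fold lower number from compound 1 to compound 3 (0.26 log units; within the scatter). The furthest is linked by an 8.6-fold lower number from compound 2 to compound 3 (0.93 log units; beyond the scatter).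

Compound 4 `COc1cc2c(Oc3ccc(NC(=O)NNC(=O)c4ccccc4)cc3)ccnc2cc1OCCCCCCC(=O)NO` carries benzamido in place of cyclohexyl on an amide-type nitrogen. Among the measured compounds shown here, no measured compound has benzamido at this place, so the estimate is indirect. The closest evidence comes from the swaps of cyclohexyl against ring-bearing aromatic groups on the same nitrogen, which ranged from within the scatter to modest. Those aromatic groups also differ among themselves, as shown by a 4.8-fold higher number from compound 1 to compound 2 (0.68 log units; beyond the scatter). Neither aromatic compound falls clearly under compound 3, so a modest step to a higher number is expected, although a result level with compound 3 would fit compound 1 at 1080 nM.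

The step expected is a 2.5-fold higher number from compound 3 to compound 4 (0.40 log units; beyond the scatter). In this assay compound 4 is estimated at 1500 nM, with an expected range from 500 nM to 4500 nM.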

Compound 4, half-maximal inhibitory concentration: 2450 nM
Compound 4: the middle estimate sits 1.6-fold (0.21 log units) below what was measured; the measured number falls inside the stated range.
By their numbers in this assay, from the lowest: compounds 3 and 1 (each within the scatter of the next); then compound 4; then compound 2.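

Benzamido on this amide-type nitrogen, which adds a carbonyl and a hydrogen-bond donor and acceptor that cyclohexyl lacks, gives weaker activity in this assay (a 4.1-fold higher number from compound 3 to compound 4 (0.61 log units; beyond the scatter)), so a non-aromatic ring is not simply interchangeable with any ring-bearing group here. Compared with the two trifluoromethyl-bearing aryl groups, benzamido separates from both, giving a 2.3-fold higher number from compound 1 to compound 4 (0.36 log units; beyond the scatter) and a 2.1-fold lower number from compound 2 to compound 4 (0.32 log units; beyond the scatter), so it does not simply match either aryl group and the position now shows graded differences among three aromatic groups. Nothing available explains these differences.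

Benzamido changes several features at once, so the carbonyl cannot be separated from the aromatic ring: an acetamido group would keep the carbonyl without that ring, and an unsubstituted phenyl would keep an aromatic ring without the carbonyl, while a cyclopentyl or a piperidine ring would test how far the cyclohexyl result extends. Going by these compounds, the seven-carbon chain ending in the hydroxamic acid is the same in all four compounds, so whether a shorter or longer chain would change this ranking remains open.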